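Dropping the bromo substituent from compound 1

The source may report more compounds than this note shows. Statements on the series, on what has been measured and on what is new or still open speak of the compounds shown alone.

Going by the values given here, compound 1 `S=C(N/N=C/c1ccc2ccccc2n1)Nc1ccc(Br)cc1` gives 54400 nM in a functional assay on HT-29 cells (Homo sapiens) for antiproliferative activity, read by sulforhodamine B assay, with a stated time of 72 h (a higher number here means a weaker inhibitor, a lower number a stronger inhibitor), the highest of the three numbers measured so far; compound 2 `Cc1ccccc1NC(=S)N/N=C/c1ccc2ccccc2n1` gives 42300 nM and compound 3 `FC(F)(F)c1ccccc1NC(=S)N/N=C/c1ccc2ccccc2n1` gives 18100 nM. Within this set, a 1.3-fold lower number from compound 1 to compound 2 (0.11 log units; within the scatter) and a 2.3-fold lower number from compound 2 to compound 3 (0.37 log units; beyond the scatter). Compound 4 `S=C(N/N=C/c1ccc2ccccc2n1)Nc1ccccc1` differs from compound 1 by hydrogen in place of bromo on an aromatic carbon. Among the compounds with values here, no measured step removes a bromo outright; the closest comparison, the step from compound 1 to compound 2, exchanges the whole 4-bromophenyl for 2-methylphenyl and stays within the scatter, so the bromo alone seems to carry little weight here. The step of a 1.1-fold lower number from compound 1 to compound 4 (0.04 log units; within the scatter) is therefore expected to amount to nothing clearly beyond the scatter in this assay. The estimate for compound 4 is 50000 nM, within 20000 nM to 125000 nM.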

Compound 4, half-maximal inhibitory concentration: 17000 nM
Estimate against measurement, compound 4: 2.9-fold (0.47 log units) above; the whole stated range lies above it.
By their numbers in this assay, from the lowest: compounds 4 and 3 (each within the scatter of the next); then compounds 2 and 1 (each within the scatter of the next).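

In this assay, the change from 4-bromophenyl to phenyl gives a 3.2-fold lower number from compound 1 to compound 4 (0.51 log units; beyond the scatter), so a bromo at this place, para to a large group, does carry weight. The unsubstituted phenyl also separates from the 2-methylphenyl, with a 2.5-fold lower number from compound 2 to compound 4 (0.40 log units; beyond the scatter), whereas a 1.1-fold lower number from compound 3 to compound 4 (0.03 log units; within the scatter) leaves hydrogen and trifluoromethyl unresolved. No supporting data on the origin of these steps are available.

Whether the step is particular to bromo stays open, since no other group is shown at this place. An amine or a carboxylic acid on this aromatic carbon would test that.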